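Trading a pyrazolyl-bearing aryl for an ethoxy-bearing one

The source may report more compounds than this note shows. Statements on the series, on what has been measured and on what is new or still open speak of the compounds shown alone.

Compound 1 `CN1CCN(CCCS(=O)(=O)c2ccc3nc(NC(=O)NC(=O)c4cccc(-n5cccn5)c4Cl)sc3c2)CC1` has been tested in an assay on HEK293 cells for displacement of a labelled ligand from growth hormone secretagogue receptor type 1 (Homo sapiens), with a stated time of 60 min (a higher number here means a weaker inhibitor, a lower number a stronger inhibitor), where compound 1 gives 8.8 nM. That is the only full number shown for this assay. Compound 2 `CS(=O)(=O)c1ccc2nc(NC(=O)NC(=O)c3ccccc3Cl)oc2c1`, which rests on a different core, reaches only the limit of this assay; in this assay compound 2 gives > 10000 nM, a limit rather than a number (the limit of > 10000 nM in this assay, at which 1 of the 2 values shown sits). Going by the values given here, compound 2 differs from compound 1 in several places at once, so the two values show only that one compound is a strong inhibitor while the other falls outside the range of the assay.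

Compound 3 `CCOc1ccc(Cl)c(C(=O)NC(=O)Nc2nc3ccc(S(=O)(=O)CCCN4CCN(C)CC4)cc3s2)c1` has not yet been measured. It keeps the core of compound 1 and differs in a single place: 2-chloro-5-ethoxyphenyl in place of 2-chloro-3-(1H-pyrazol-1-yl)phenyl on a carbonyl carbon. The chlorine stays, the five-membered ring with two heteroatoms leaves, and an ethoxy group enters. Among the compounds with values here, no measured pair shows this change, so its size is unknown; the step from compound 1 to compound 3 is expected to be small, a 2.3-fold higher number from compound 1 to compound 3 (0.36 log units; beyond the scatter), perhaps slightly weakening. Compound 3 is therefore estimated at 20 nM, within 5 nM to 80 nM.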

Compound 3, half-maximal inhibitory concentration in the growth hormone secretagogue receptor type 1 assay: 0.31 nM
For compound 3 the middle estimate is 65-fold (1.81 log units) above the measured one; the whole stated range lies above it.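

In the growth hormone secretagogue receptor type 1 assay, 2-chloro-5-ethoxyphenyl in place of 2-chloro-3-(1H-pyrazol-1-yl)phenyl on a carbonyl carbon gives a 28-fold lower number from compound 1 to compound 3 (1.45 log units; beyond the scatter), so this place on the molecule has a strong hold on binding, and strong inhibition does not depend on the five-membered aromatic ring with its two hetero atoms. The entering group is the one with fewer heavy atoms and one hydrogen-bond acceptor fewer, so in this pair the stronger inhibitor is the compound with the smaller group. The gain does not come alone, since the same change also raises the distribution coefficient in a physicochemical assay for lipophilicity; on this read-out lower numbers stand for lower lipophilicity and higher numbers for higher lipophilicity: the measured distribution coefficient of compound 1, 1.6, and of compound 3, 2.4, a number 0.80 log units higher (beyond the scatter) In the physicochemical assay compound 1 gives 1.6 and compound 3 gives 2.4.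

With a single pair, the compounds shown cannot tell whether the stronger inhibition comes from the ethoxy group itself, from the loss of the pyrazolyl group, or from the different place of the substituent in the two group names. Also open, from the compounds shown here alone, is how 2-chloro-3-ethoxyphenyl, a methoxy group or a longer propoxy chain would behave here, and whether an added carboxylic acid would bring the distribution coefficient back down while keeping the binding.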